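The source may hold more compounds than are shown below. What is called first, only, known or untested is meant among the compounds shown, and "the series" means these compounds.

Of the compounds shown here, three built on one shared core have been measured in an ADME assay on HepG2 cells (Homo sapiens) for cytotoxicity, read by luminescence, CellTiter-Glo and ATP content, with a stated time of 72 h; on this read-out higher numbers stand for an effect only at larger amounts of compound and lower numbers for an effect already at smaller amounts. Compound 1 `COc1cccc(Oc2ccc3c(NCCCNCc4cc(F)ccc4OC)ccnc3c2)c1` gives 7100 nM. Compound 2 `COc1ccc(F)cc1CNCCCNc1ccnc2cc(Cc3ccccc3)ccc12` gives 7990 nM in this assay, and compound 3 `COc1ccc(F)cc1CNCCCNc1ccnc2cc(Cc3cccc(C(F)(F)F)c3)ccc12` gives 440 nM. Compound 3 stands lowest of the three: the step of a 16-fold lower number from compound 1 to compound 3 (1.21 log units; beyond the scatter) and the step of an 18-fold lower number from compound 2 to compound 3 (1.26 log units; beyond the scatter) both lie beyond the scatter, whereas the step of a 1.1-fold higher number from compound 1 to compound 2 (0.05 log units; within the scatter) lies within it.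

Compound 4 `COc1ccc(F)cc1CNCCCNc1ccnc2cc(Oc3ccccc3OC)ccc12` has not yet been measured in this assay. It differs from compound 3 in one place: 2-methoxyphenoxy in place of 3-(trifluoromethyl)benzyl on an aromatic carbon. Among the measured compounds shown here, two measured steps bear on this change. The step of a 16-fold lower number from compound 1 to compound 3 (1.21 log units; beyond the scatter) is nearly the reverse of it, a methoxyphenoxy group giving way to the 3-(trifluoromethyl)benzyl group, and the step of an 18-fold lower number from compound 2 to compound 3 (1.26 log units; beyond the scatter) shows that the trifluoromethyl alone carries most of that move. Because compound 1 with its 3-methoxyphenoxy group gives 7100 nM, compound 4 is expected to return to that neighbourhood, an upward step of a 15-fold higher number from compound 3 to compound 4 (1.17 log units; beyond the scatter). The estimate for compound 4 in this assay is 6500 nM, with a range from 2500 nM to 17000 nM.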

Compound 4, half-maximal effective concentration: 6400 nM
Estimate against measurement, compound 4: 1.0-fold (0.01 log units) above, and the stated range covers the measured number.
By their numbers in this assay, from the lowest: compound 3; then compounds 4, 1 and 2 (each within the scatter of the next).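

Set against compound 3 directly, the step of a 15-fold higher number from compound 3 to compound 4 (1.16 log units; beyond the scatter) in this assay shows that this position, on an aromatic carbon of the shared core, tolerates no free exchange of 3-(trifluoromethyl)benzyl for 2-methoxyphenoxy: the change is large and lies beyond the scatter. Moving the methoxy group on the phenoxy ring registers no such effect, since the step of a 1.1-fold lower number from compound 1 to compound 4 (0.05 log units; within the scatter) lies within the scatter, and exchanging benzyl for 2-methoxyphenoxy does not either, with the step of a 1.2-fold lower number from compound 2 to compound 4 (0.10 log units; within the scatter) also within it. Compounds 1, 2 and 4 thus form one group within the scatter of each other, and compound 3, the only one of the four with a trifluoromethyl group, stands apart, although no measurement shown here explains that separation.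

On these data alone, it remains open whether the trifluoromethyl group would have the same effect on a phenoxy group, as in 3-(trifluoromethyl)phenoxy, or whether it depends on the benzyl group that carries it in compound 3. Also open, as far as these compounds go, is whether a chlorine or a nitrile in place of the trifluoromethyl would give a similar number.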